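The source may hold more compounds than are shown below. What is called first, only, known or untested is meant among the compounds shown, and "the series" means these compounds.

Results so far in a functional assay on A549 cells (Homo sapiens) for antiproliferative activity, read by MTT assay, with a stated time of 72 h (a higher number here means a weaker inhibitor, a lower number a stronger inhibitor), are these
- compound 1 `Cc1ccccc1NC(=O)C(Cl)Cl` has the entry "not determined" (no result reported) and so offers no comparison
- compound 2 `O=C(Nc1ccccc1F)C(Cl)Cl` gives 87500 nM as its value
- compound 3 `O=C(Nc1ccccc1[N+](=O)[O-])C(Cl)Cl` gives 198000 nM as its value

Going by the values given here, of the two actual numbers, the one for compound 2 is the lower, so it is the stronger inhibitor of this pair. The next compound to be tested is compound 4 `O=C(Nc1ccccc1NC(=O)C(Cl)Cl)C(Cl)Cl`, which is built from compound 2 by one change at a single place. Here the difference counts out as ((dichloromethyl)carbonyl)amino in place of fluoro on an aromatic carbon in full.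

Among the compounds with values here, only one measured step bears on this change, since it also replaces that fluoro, in that case with nitro. That step is a 2.3-fold higher number from compound 2 to compound 3 (0.35 log units; beyond the scatter) and it is modest, though beyond the scatter. A single step with a different group is thin evidence, and it cannot show how a much larger group will behave. A small move towards a higher number therefore seems the most reasonable expectation, with the direction far from certain. The expected change is a 1.5-fold higher number from compound 2 to compound 4 (0.17 log units; within the scatter) on this reading. Compound 4 is estimated at 130000 nM with an expected range from 40000 nM to 350000 nM as a working guess.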

Compound 4, half-maximal inhibitory concentration: 131000 nM
The estimate for compound 4 lay 1.0-fold (0.00 log units) below the measured number; the range from low to high includes it.
By their numbers in this assay, from the lowest: compounds 2, 4 and 3 (each within the scatter of the next, the first and the last beyond it).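

In this assay, the aromatic carbon takes a far larger group without a clear shift in the number: replacing fluoro with ((dichloromethyl)carbonyl)amino, which brings a hydrogen-bond donor and a hydrogen-bond acceptor, gives a 1.5-fold higher number from compound 2 to compound 4 (0.18 log units; within the scatter) in this comparison. Replacing nitro with the same group gives a 1.5-fold lower number from compound 3 to compound 4 (0.18 log units; within the scatter) here, so compound 4 cannot be told apart from either of the other two, even though the earlier comparison, a 2.3-fold higher number from compound 2 to compound 3 (0.35 log units; beyond the scatter) as printed, had separated those two from each other. Nothing measured here explains why so large a swap leaves the number within the scatter.

Compound 1 gives "not determined" (no result reported) as its entry, so it adds no further comparison at this position. Going by these compounds, it remains open whether an amine or a carboxylic acid on this aromatic carbon would give a number clearly apart from these, and whether an acetylamino group, which has no chlorine atoms, would behave like ((dichloromethyl)carbonyl)amino.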